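Butyl amide in place of tert-butyl ester on a shared core

The compounds below may be only part of what the source reports. "The series", "measured", "known", "first", "only" and "open" are said of these compounds alone.

For the measured compounds named here, compound 1 `COc1ccc2c(c1)OC(c1cc(OC)c(OC)c(OC)c1)C(C(=O)OC(C)(C)C)=C2` holds the only number in a functional assay for inhibition of nuclear factor NF-kappa-B complex (Homo sapiens) (on this read-out lower numbers stand for stronger inhibition and higher numbers for weaker inhibition), where compound 1 gives 14100 nM. Compound 2 `COc1ccc2c(c1)OC(c1cc(OC)c(OC)c(OC)c1)C(C(=O)O)=C2` reaches only a limit of this assay and is recorded as > 50000 nM. Going by the values given here, the single measured step, hydrogen in place of tert-butyl on an oxygen next to a carbonyl group, is an at least 3.5-fold higher number from compound 1 to compound 2 (0.54 log units; beyond the scatter), and the value of compound 2 sits at the limit of > 50000 nM in this assay, at which 1 of the 2 values shown sits. Compound 3 `CCCCNC(=O)C1=Cc2ccc(OC)cc2OC1c1cc(OC)c(OC)c(OC)c1` differs from compound 1 at that same carbonyl carbon: butylamino in place of tert-butoxy on a carbonyl carbon. The measured step bears on it only in part, since compound 3 keeps a butyl chain within the butylamino group rather than the free acid of compound 2. The account therefore expects no step beyond the scatter in this assay, the expected step being a 1.1-fold higher number from compound 1 to compound 3 (0.03 log units; within the scatter). Compound 3 is estimated at 15000 nM, within a range of 5000 nM to 45000 nM.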

Compound 3, half-maximal inhibitory concentration: 25500 nM
For compound 3 the middle estimate is 1.7-fold (0.23 log units) below the measured one; the measured number falls inside the stated range.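

At the carbonyl carbon, butylamino in place of tert-butoxy gives a 1.8-fold higher number from compound 1 to compound 3 (0.26 log units; within the scatter), so in this assay an amide at this position reads the same as the ester of compound 1 within the usual scatter. Set against the free acid, the step is an at least 1.9-fold lower number from compound 2 to compound 3 (0.29 log units; that floor lies within the scatter), and that floor alone does not set compound 3 apart from compound 2. Compound 2 stands at a limit of the assay, not at a number: the limit of > 50000 nM in this assay, at which 1 of the 3 values shown sits.

From the compounds shown here alone, whether a tert-butylamino group, the direct counterpart of tert-butoxy, or a longer chain on the amide nitrogen would move the number beyond the scatter stays open. So does the role of the amide hydrogen, which a tertiary amide such as an N-methyl-N-butyl amide would address.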